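Working notes: amine-side substituent swap in one series

This account rests on a few compounds, and the source may have more. Where it says the series, first, only, none or still open, it means among the compounds named here.

Measured so far in an assay on cells with melanin-concentrating hormone receptor 1 (Homo sapiens) as the target, read by radioligand binding; a higher number here means a weaker inhibitor, a lower number a stronger inhibitor:
compound 1 `CC(CNCC1CC1)Oc1cccc2ccc(N)nc12` gives 80 nM
compound 2 `CC(CNCC1CCCC1)Oc1cccc2ccc(N)nc12` gives 100 nM
compound 3 `CC(CNCc1ccoc1)Oc1cccc2ccc(N)nc12` gives 10 nM

Compound 2 stands at the highest number of the three; its nearest neighbour is compound 1, the step being a 1.3-fold higher number from compound 1 to compound 2 (0.10 log units; within the scatter). Within the data shown here, the one step that stands beyond the scatter is a 10-fold lower number from compound 2 to compound 3 (1.00 log units; beyond the scatter), matched by an 8.0-fold lower number from compound 1 to compound 3 (0.90 log units; beyond the scatter).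

Compound 4 `CC(CNCc1ccsc1)Oc1cccc2ccc(N)nc12` is not yet measured. Its difference from compound 2: thiophen-3-yl in place of cyclopentyl on a saturated chain carbon bound to an amine nitrogen. Among the measured compounds shown here, the bearing step is the one from compound 2 to compound 3, which also placed a five-membered aromatic ring with one hetero atom on the same carbon and gave a lower number. A comparable step is therefore expected for compound 4, estimated as a 6.7-fold lower number from compound 2 to compound 4 (0.82 log units; beyond the scatter), toward a lower number. Compound 4 is estimated at 15 nM, range 5 nM to 50 nM.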

Compound 4, half-maximal inhibitory concentration: 10 nM
For compound 4 the middle estimate is 1.5-fold (0.18 log units) above the measured one, and the stated range covers the measured number.
By their numbers in this assay, from the lowest: compounds 3 and 4 (each within the scatter of the next); then compounds 1 and 2 (each within the scatter of the next).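

In this assay, the lower number at this carbon is not peculiar to furan-3-yl: thiophen-3-yl in place of a saturated ring also lowers it (a 10-fold lower number from compound 2 to compound 4 (1.00 log units; beyond the scatter); an 8.0-fold lower number from compound 1 to compound 4 (0.90 log units; beyond the scatter)). Exchanging one aromatic ring for the other, with sulfur in place of oxygen as the ring hetero atom, leaves the number unmoved (no change at the digits printed from compound 3 to compound 4 (within the scatter)). No measurement at hand explains the separation of the aromatic from the saturated rings.

On these data alone, whether phenyl, with no ring hetero atom, would keep the lower number remains open.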